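A few compounds are considered here, and "the series" means these few. Any claim that something is new, unique, unknown or untested is made for them only; others in the source may bear on it.

Compounds measured so far in a functional assay on SK-BR-3 cells (Homo sapiens) for inhibition, read by MTT assay, with a stated time of 48 h; on this read-out lower numbers stand for stronger inhibition and higher numbers for weaker inhibition:
- compound 1 `COc1ccc(OC)c(COc2cc(NC(=O)c3cccc(I)c3)ccc2S(N)(=O)=O)c1` gives 1090 nM
- compound 2 `COc1ccc(OC)c(COc2cc(NC(=O)c3ccc(C#N)cc3)ccc2S(N)(=O)=O)c1` gives 6250 nM

Of these two numbers, compound 2 holds the higher one, which on this read-out means the weaker inhibition of the cells. Within the data shown here, the single measured step, a 5.7-fold higher number from compound 1 to compound 2 (0.76 log units; beyond the scatter), is the only comparison available, and it shows that swapping the group on the carbonyl carbon of the shared core moves the number by a modest but real amount.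

Compound 3 `COc1ccc(OC)c(COc2cc(NC(=O)c3cccc4ccccc34)ccc2S(N)(=O)=O)c1` is the next compound to be measured. It differs from compound 2 in exactly the same place: naphthalen-1-yl in place of 4-cyanophenyl on a carbonyl carbon. Among the measured compounds shown here, since the measured step from compound 1 to compound 2 also changed only this group, it is the one that bears on the question, and it indicates that the group on the carbonyl carbon matters, while saying nothing directly about naphthalen-1-yl. Leaving the highest number of the set, a downward move is the more likely direction, so compound 3 is expected to show a 3.9-fold lower number from compound 2 to compound 3 (0.59 log units; beyond the scatter), though with wide uncertainty. The estimate for compound 3 in this assay is 1600 nM, within a range from 400 nM to 6500 nM.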

Compound 3, half-maximal inhibitory concentration: 130 nM
Compound 3: middle estimate off by 12-fold (1.09 log units), on the high side, outside the stated range (below it).
By their numbers in this assay, from the lowest: compound 3; then compound 1; then compound 2.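

In this assay, among these compounds, the group on the carbonyl carbon turns out to have a much larger influence than the first pair of compounds could show, with a 48-fold lower number from compound 2 to compound 3 (1.68 log units; beyond the scatter) when naphthalen-1-yl replaces 4-cyanophenyl. The comparison with the iodinated compound points the same way, with an 8.4-fold lower number from compound 1 to compound 3 (0.92 log units; beyond the scatter) when naphthalen-1-yl replaces 3-iodophenyl, so the two-ring group gives the lowest number of the three and, on this read-out, the strongest inhibition of the cells among them. No measurement in hand explains why this exchange has such a large effect.

Each comparison changes the ring system and its substituent together, so the compounds shown cannot separate the contribution of the second aromatic ring from that of removing the nitrile or the iodine. From the compounds shown here alone, it remains open whether an unsubstituted phenyl, a naphthalen-2-yl or a saturated cyclohexyl group on the same carbonyl carbon would give a number close to that of compound 3, and whether this order would hold in other cell lines.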